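Halogen Swap at the Anilide Ring: Chloro to Bromo

This account rests on a few compounds, and the source may have more. Where it says the series, first, only, none or still open, it means among the compounds named here.

Of the compounds shown here, two that share one core have been measured in a functional assay on NCI-H1975 cells (Homo sapiens) for inhibition, read by MTT assay, with a stated time of 72 h; on this read-out higher numbers stand for weaker inhibition and lower numbers for stronger inhibition. Compound 1 `O=C(CSc1nc(Nc2ccccc2)c2ccccc2n1)Nc1ccccc1F` gives 9350 nM. Compound 2 `O=C(CSc1nc(Nc2ccccc2)c2ccccc2n1)Nc1ccccc1Cl` gives 9610 nM, and stands as the higher of the two numbers, although the step of a 1.0-fold higher number from compound 1 to compound 2 (0.01 log units; within the scatter) lies within the scatter, so the two compounds cannot be ranked. Compound 3 `O=C(CSc1nc(Nc2ccccc2)c2ccccc2n1)Nc1ccccc1Br` carries the change (bromo in place of chloro on an aromatic carbon). Among the compounds with values here, the only measured step that bears on this change is the earlier halogen swap, a 1.0-fold higher number from compound 1 to compound 2 (0.01 log units; within the scatter), which was too small to stand apart from the scatter. On that basis the step to compound 3 is expected to be a 1.0-fold lower number from compound 2 to compound 3 (0.00 log units; within the scatter), with no direction beyond the scatter. For compound 3 the estimate in this assay is 9600 nM, with a range from 5000 nM to 18000 nM.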

Compound 3, half-maximal inhibitory concentration: 10300 nM
Compound 3: middle estimate off by 1.1-fold (0.03 log units), on the low side; low and high end bracket the measured number.
By their numbers in this assay, from the lowest: compounds 1, 2 and 3 (each within the scatter of the next).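

Bromo gives a third halogen on this aromatic carbon, and in this assay the change again makes little difference: the step is a 1.1-fold higher number from compound 2 to compound 3 (0.03 log units; within the scatter) and the wider comparison is a 1.1-fold higher number from compound 1 to compound 3 (0.04 log units; within the scatter) with both lying within the scatter. The earlier pair covered only fluoro and chloro, whereas fluoro, chloro and bromo now cannot be told apart at this position in compounds 1, 2 and 3, so the flat result extends across all three halogens. Nothing is available that would explain this result.

As far as these compounds go, whether a group other than a halogen at this place, such as a methoxy group, an amine or a nitrile, would separate from these three compounds remains open. From the compounds shown here alone, it is also open whether a halogen on another carbon of this ring, or the bare 2-unsubstituted phenyl, would give a number beyond the scatter.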